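Replacing Thiophen-3-yl with 2-Methoxyphenyl on a Shared Core

The compounds below may be only part of what the source reports. "The series", "measured", "known", "first", "only" and "open" are said of these compounds alone.

Compound 1 `Fc1ccc(-c2cn3ccnc3c(-c3ccc4ncn(C5CCCCC5)c4c3)n2)cc1` gives 7.94% in a functional assay on U-251 cells (Homo sapiens) for inhibition, read by sulforhodamine B assay, with a stated time of 48 h, tested at 10 uM; a higher number here means more inhibition at the concentration tested (going by the name of the read-out), a lower number less inhibition.
Compound 2 `c1cn2cc(-c3ccsc3)nc(-c3ccc4ncn(C5CCCCC5)c4c3)c2n1` gives 6.09% in this assay.

Among the compounds with values here, both numbers are small, and the only step so far, a number 1.9 percentage points lower from compound 1 to compound 2 (within the scatter), lies within the scatter, so compound 2 has the lower of the two values without that meaning any real difference from compound 1.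

Compound 3 `COc1ccccc1-c1cn2ccnc2c(-c2ccc3ncn(C4CCCCC4)c3c2)n1` differs from compound 2 in one place: 2-methoxyphenyl in place of thiophen-3-yl on an aromatic carbon. Within the data shown here, the one measured step that bears on this, a number 1.9 percentage points lower from compound 1 to compound 2 (within the scatter), exchanged a group at the same place and moved the number hardly at all. Among the measured compounds shown here, with only that step as guidance, the expected change a number 1.9 percentage points higher from compound 2 to compound 3 (within the scatter) is estimated to be none beyond the scatter, in either direction. Compound 3 is therefore expected to give about 8% in this assay, within a range from 0% to 22%.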

Compound 3, a percentage reported as inhibition, at one concentration (the size of the read-out at that concentration, not a potency): 21%
Compound 3: the middle estimate sits 13 percentage points below what was measured; the range from low to high includes it.
By their numbers in this assay, from the lowest: compounds 2 and 1 (each within the scatter of the next); then compound 3.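

In this assay, this position turns out not to be indifferent to the group placed on it: 2-methoxyphenyl in place of thiophen-3-yl gives a number 14.9 percentage points higher from compound 2 to compound 3 (beyond the scatter), and 2-methoxyphenyl in place of 4-fluorophenyl gives a number 13.1 percentage points higher from compound 1 to compound 3 (beyond the scatter). The earlier exchange between the two other groups produced no step beyond the scatter, so 2-methoxyphenyl is the first group shown here to separate from the others. These are still readings at a single concentration and do not measure potency, and no available evidence accounts for the difference.

Going by these compounds, whether a hydroxyl group, an amine or a longer ether chain on the phenyl ring would raise the number further remains open. So does whether the effect of 2-methoxyphenyl would persist if the cyclohexyl group on the shared core were replaced.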